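The source may hold more compounds than are shown below. What is called first, only, known or untested is meant among the compounds shown, and "the series" means these compounds.

Compound 1 `COc1ccc(N2C[C@@H](C)N[C@@H](C)C2)cc1NS(=O)(=O)c1ccc(-c2ccccn2)s1` is the anchor of this small set. In a functional assay for agonist activity at growth hormone secretagogue receptor type 1 (Homo sapiens), read by FLIPR (on this read-out lower numbers stand for smaller maximal responses and higher numbers for larger maximal responses), compound 1 gives 1.1, the highest of the three numbers in hand. Compound 2 `C[C@@H]1CN(c2ccc(Cl)c(NS(=O)(=O)c3ccc(-c4ccccn4)s3)c2)C[C@H](C)N1` gives 1 in the same read-out, and compound 3 `CC(=O)c1ccc(N2C[C@@H](C)N[C@@H](C)C2)cc1NS(=O)(=O)c1ccc(-c2ccccn2)s1` gives 0.9. The step a number 0.10 lower from compound 1 to compound 2 (within the scatter) is within the scatter; the step a number 0.20 lower from compound 1 to compound 3 (beyond the scatter) is beyond it, though modest; the step a number 0.10 lower from compound 2 to compound 3 (within the scatter) is again within it. All three of these steps vary the group on an aromatic carbon of the shared core and leave the pyridin-2-yl untouched.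

Compound 4 `COc1ccc(N2C[C@@H](C)N[C@@H](C)C2)cc1NS(=O)(=O)c1ccc(-c2cnco2)s1` is still to be measured. It differs from compound 1 in one place: 1,3-oxazol-5-yl in place of pyridin-2-yl on an aromatic carbon. Among the measured compounds shown here, no measured step touches this part of the molecule, so the series gives no direct guide to the change. What the series does show is that all three measured compounds reach a full or near-full response in this assay, the widest spread being a number 0.20 lower from compound 1 to compound 3 (beyond the scatter). On that basis no step beyond the scatter is expected, a number 0.10 lower from compound 1 to compound 4 (within the scatter), with any drift most likely downward as seen for the other changes. Compound 4 is therefore estimated at 1, with a range from 0.8 to 1.1.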

Compound 4, intrinsic activity: the largest response reached, as a fraction of the reference agonist's: 0.9
Compound 4: middle estimate off by 0.10, on the high side, within the range that was stated.
By their numbers in this assay, from the lowest: compounds 3, 4, 2 and 1 (each within the scatter of the next, the first and the last beyond it).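

The position next to the ring sulfur now has its first measured step: in this assay, 1,3-oxazol-5-yl in place of pyridin-2-yl gives a number 0.20 lower from compound 1 to compound 4 (beyond the scatter), so a change at this position can move the maximal response beyond the scatter, though only modestly. The step matches in size the one at the other varied position, a number 0.20 lower from compound 1 to compound 3 (beyond the scatter), while the chloro step, a number 0.10 lower from compound 1 to compound 2 (within the scatter), stays within the scatter, so changes at the two positions of compound 1 do not all behave alike. No measured data here account for the step at the position next to the ring sulfur.

Since the two rings differ in both ring size and hetero atoms, this single step does not separate the two, and a phenyl or a 1,3-thiazol-5-yl at the same position would be needed to tell them apart. Also open, as far as these compounds go, is how this position responds to a non-aromatic group such as an aminomethyl or a carboxylic acid, and whether 1,3-oxazol-5-yl combines with the chloro or acetyl group on the shared core without a further fall in response.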